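Swapping the tert-butylphenyl amide for a nitrophenyl amide

A few compounds are considered here, and "the series" means these few. Any claim that something is new, unique, unknown or untested is made for them only; others in the source may bear on it.

Measured compounds:
- compound 2, `CC(C)(C)c1ccc(C(=O)Nc2cccc(NC(=O)COc3ccc4c(=O)ccoc4c3)c2)cc1`, which in an assay on isolated protein for inhibition of Rho-associated protein kinase 1 (Homo sapiens), read by scintillation counting, radiometric assay and 33P incorporation, with a stated time of 40 min, in the presence of a further agent that is not named here (on this read-out higher numbers stand for weaker inhibition and lower numbers for stronger inhibition), gives 165 nM
- compound 1, `COc1ccc(OCC(=O)Nc2cccc(NC(=O)c3ccc(N(C)C)cc3)c2)cc1F`, which in this assay gives 1820 nM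

Compound 2 holds the lowest of the two numbers. Its nearest neighbour on this scale is compound 1, whose number is higher by a gap that lies beyond the usual scatter; the two structures differ in more than one place, so the pair shows only its two values and nothing about any single change.

Compound 3, `O=C(COc1ccc2c(=O)ccoc2c1)Nc1cccc(NC(=O)c2cccc([N+](=O)[O-])c2)c1`, differs from compound 2 in one place: 3-nitrophenyl in place of 4-(tert-butyl)phenyl on a carbonyl carbon. Going by the values given here, no pair of measured compounds separated by a single change is available, so there is no measured step to rest on. The 3-nitrophenyl brings two hydrogen-bond acceptors where the 4-(tert-butyl)phenyl had none, and the author expects compound 3 to come out somewhat weaker than compound 2, with a step estimated as a 2.7-fold higher number from compound 2 to compound 3 (0.44 log units; beyond the scatter) in this assay, a shift that may or may not clear the scatter. The estimate for compound 3 in this assay is 450 nM, within a range from 150 nM to 1500 nM.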

Compound 3, half-maximal inhibitory concentration: 528 nM
The estimate for compound 3 lay 1.2-fold (0.07 log units) below the measured number; the measured number falls inside the stated range.
By their numbers in this assay, from the lowest: compound 2; then compound 3; then compound 1.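

Going by these compounds alone, with the rest of the molecule held fixed, the step in this assay is a 3.2-fold higher number from compound 2 to compound 3 (0.51 log units; beyond the scatter), which shows for the first time that the aryl group on this carbonyl carbon, whose other neighbour is an amide-type nitrogen, bears on the number by itself. The step is modest, and the exchange of 4-(tert-butyl)phenyl for 3-nitrophenyl leaves a measurable value, with compound 3 at 528 nM, so this position accepts two quite different aryl groups without the reading being lost. No separate measurement bears on what lies behind the shift.

This single exchange changes both the substituent and its place on the ring, so the compounds shown cannot tell whether the shift follows from the loss of the tert-butyl group, the arrival of the nitro group or the new placement. From the compounds shown here alone, how a plain phenyl, an aminophenyl or a carboxyphenyl on the same carbonyl carbon would read in this assay remains open, as does whether this step would hold on a different core.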